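Taking the Fluorine Off the Aryl Ring

This account rests on a few compounds, and the source may have more. Where it says the series, first, only, none or still open, it means among the compounds named here.

Compound 3 `CCC(C(=O)N1CCN(c2ccccc2F)CC1)N1C(=O)CCC1=O` gives 0% in a functional assay on the whole organism (strain Swiss) with Mus musculus as the target, in the maximal electroshock model, with a stated time of 2 h, at a dose of 300 mg/kg by the intraperitoneal route; on this read-out higher numbers stand for a stronger effect at the one dose given and lower numbers for a weaker effect. That number sits level with compound 1 `CCC(C(=O)N1CCN(c2cccc(OC)c2)CC1)N1C(=O)CCC1=O`, which gives 0%, and together these two are the lowest of the three measured values; the step of no change at the digits printed from compound 1 to compound 3 (within the scatter) shows the change in the aryl group made no difference. Compound 2 `CC(C(=O)N1CCN(c2ccccc2F)CC1)N1C(=O)CCC1=O` gives 25%, and the step of a number 25 percentage points lower from compound 2 to compound 3 (beyond the scatter) is a modest fall.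

Compound 4 `CCC(C(=O)N1CCN(c2ccccc2)CC1)N1C(=O)CCC1=O` differs from compound 3 by hydrogen in place of fluoro on an aromatic carbon. Within the data shown here, the only step that touched the aryl group, no change at the digits printed from compound 1 to compound 3 (within the scatter), stayed flat, so no shift beyond the scatter is expected for this assay. Compound 4 is therefore estimated at 5%, with a range from 0% to 25%, a step of a number 5 percentage points higher from compound 3 to compound 4 (within the scatter).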

Compound 4, a percentage reported as activity, at one dose (the size of the read-out at that dose, not a potency): 25%
For compound 4 the middle estimate is 20 percentage points below the measured one; low and high end bracket the measured number.
By their numbers in this assay, from the lowest: compounds 1 and 3 (each within the scatter of the next); then compounds 2 and 4 (each within the scatter of the next).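

In this assay, the aryl group does matter: hydrogen in place of fluoro gives a number 25 percentage points higher from compound 3 to compound 4 (beyond the scatter), and hydrogen in place of methoxy gives a number 25 percentage points higher from compound 1 to compound 4 (beyond the scatter). The earlier flat step between the two substituted rings therefore hid a difference that appears only against the unsubstituted phenyl ring. No measured evidence explains this change.

As far as these compounds go, it remains open whether a chloro or a hydroxy group on this ring would also go with the lower number, and whether phenyl would change the number of compound 2.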